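Series notes: tert-butyl removal at the para carbon of compound 1

The source may report more compounds than this note shows. Statements on the series, on what has been measured and on what is new or still open speak of the compounds shown alone.

Measured so far:
compound 1 `CC(C)(C)c1ccc(-c2cn(C/C=C3\OC(=O)C(OCc4ccccc4)=C3OCc3ccccc3)nn2)cc1` — in a functional assay on U-937 cells (Homo sapiens) for antiproliferative activity, read by MTT assay, with a stated time of 24 h (on this read-out lower numbers stand for stronger inhibition and higher numbers for weaker inhibition), compound 1 gives > 100000 nM, a limit of the assay and not a number.
compound 2 `CCCc1cn(CCC2(O)C(OCc3ccccc3)=C(OCc3ccccc3)C(=O)N2CCC)nn1` — in this assay compound 2 gives > 100000 nM, also a limit.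
compound 3 `CCCCCCCCN1C(=O)C(OCc2ccccc2)=C(OCc2ccccc2)C1(O)CCn1cc(-c2ccccn2)nn1` — in this assay compound 3 gives 84200 nM.

Within the data shown here, compound 1 therefore stands at the limit of > 100000 nM in this assay, at which 2 of the 3 values shown sit; only a limit is known for it, and no step between measured compounds exists. Compound 4 `O=C1O/C(=C\Cn2cc(-c3ccccc3)nn2)C(OCc2ccccc2)=C1OCc1ccccc1` differs from compound 1 by hydrogen in place of tert-butyl on an aromatic carbon. Nothing measured shows what this change does in this assay; a step of no more than the usual scatter is expected, in no set direction. Compound 4 is expected to give about 150000 nM (range 60000 nM to 400000 nM) in this assay, most likely again reported only as a limit. The implied step, a step that the limit leaves unreadable from compound 1 to compound 4, is expected to be none beyond the scatter.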

Compound 4, half-maximal inhibitory concentration: > 100000 nM
Compound 4: a limit, no number (the forecaster's own chance of this, stated with the estimate: 80%); the middle value is on the limit's open side.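

Compound 1 and compound 4 are both reported only as limits in this assay, and the step between them cannot be read: the limit of > 100000 nM in this assay, at which 3 of the 4 values shown sit.

On these data alone, what the change from 4-(tert-butyl)phenyl to phenyl does on the shared core in this assay remains open.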